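Swapping Cyclopropyl for Oxanyl on a Limit-Level Amide

The source may hold more compounds than are shown below. What is called first, only, known or untested is meant among the compounds shown, and "the series" means these compounds.

Compound 1 `O=C1NCCc2nc(C#Cc3ccccc3)sc21` is active in an assay on HEK293 cells for positive allosteric modulation of metabotropic glutamate receptor 5 (Homo sapiens), read by FLIPR, with a stated time of 1 h (a higher number here means that more compound is needed for the effect, a lower number that less compound is needed), where compound 1 gives 112 nM. Compound 2 `O=C(C1CC1)N1CCc2nc(C#Cc3ccccc3)sc2C1` carries a cyclopropyl on an amide carbonyl of a different core. In this assay compound 2 reaches only > 10000 nM, which is a limit of the measurement rather than a number (the limit of > 10000 nM in this assay, at which 1 of the 2 values shown sits). Compound 3 `O=C(C1CCOCC1)N1CCc2nc(C#Cc3ccccc3)sc2C1` differs from compound 2 in one place: oxan-4-yl in place of cyclopropyl on a carbonyl carbon. The step of a number no higher from compound 2 to compound 3 (the limit leaves the size open) is expected to stay within the scatter, given that compound 2 already sits at the limit of > 10000 nM in this assay, at which 1 of the 2 values shown sits. Compound 3 is therefore estimated at 10000 nM, within 3000 nM to 30000 nM.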

Compound 3, half-maximal effective concentration: 290 nM
The estimate for compound 3 lay 34-fold (1.54 log units) above the measured number, and the stated range ends above it.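

Oxan-4-yl in place of cyclopropyl on a carbonyl carbon gives an at least 34-fold lower number from compound 2 to compound 3 (1.53 log units; beyond the scatter) in this assay. Compound 2 stands at a limit, so the full size of this step stays open: the limit of > 10000 nM in this assay, at which 1 of the 3 values shown sits.

The core of compound 2 is thus not inactive in itself, as a single change at this carbonyl carbon brings it to a measurable number. The compounds shown cannot tell whether the ring oxygen or the larger ring matters. A cyclohexyl group, with carbon in place of that oxygen, would separate the two.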